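Notes on lengthening the ester of compound 2

The source may report more compounds than this note shows. Statements on the series, on what has been measured and on what is new or still open speak of the compounds shown alone.

Measured so far in a functional assay on A549 cells (Homo sapiens) for inhibition, read by MTT assay, with a stated time of 72 h; a lower number here means a stronger inhibitor of growth, a higher number a weaker inhibitor of growth:
Compound 1 `CC1(C)CCC[C@]2(C)[C@@H](C=O)C(C=O)=CC[C@@H]12` gives 90000 nM
Compound 2 `COC(=O)/C=C/C1=CC[C@H]2C(C)(C)CCC[C@]2(C)[C@H]1C=O` gives 21000 nM

Within the data shown here, with only two numbers in hand, compound 2 (21000 nM) is the lower of the pair and thus the stronger growth inhibitor in this assay so far. Compound 3 `CCOC(=O)/C=C/C1=CC[C@H]2C(C)(C)CCC[C@]2(C)[C@H]1C=O` has not been measured. It differs from compound 2 by one change, (methyl in place of hydrogen on a saturated chain carbon bound to an oxygen next to a carbonyl group), which reads as methoxycarbonyl to ethoxycarbonyl.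

Among the measured compounds shown here, the only measured step is a 4.3-fold lower number from compound 1 to compound 2 (0.63 log units; beyond the scatter), with 2-(methoxycarbonyl)ethenyl in place of formyl on a double-bonded ring carbon. For the measured compounds named here, that step introduced the ester group but says nothing directly about methoxy to ethoxy, and no measured pair varies this part of the structure. Its size therefore cannot be carried over, and the data give no direction for the new change. No step beyond the scatter is expected in this assay, so the estimate stays anchored on compound 2 (21000 nM), with a wide range to reflect the thin evidence. The expected change is a 1.1-fold lower number from compound 2 to compound 3 (0.02 log units; within the scatter) in this estimate. For compound 3 the estimated value is 20000 nM, with an expected range from 10000 nM to 42000 nM.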

Compound 3, concentration for 50% growth inhibition: 25000 nM
Compound 3: middle estimate off by 1.3-fold (0.10 log units), on the low side; the measured number falls inside the stated range.
By their numbers in this assay, from the lowest: compounds 2 and 3 (each within the scatter of the next); then compound 1.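

In this assay, among these compounds, the exchange of methoxycarbonyl for ethoxycarbonyl gives a 1.2-fold higher number from compound 2 to compound 3 (0.08 log units; within the scatter), the first reading at this position: methyl in place of hydrogen on a saturated chain carbon bound to an oxygen next to a carbonyl group leaves the number within the scatter, and compounds 2 and 3 cannot be ordered. The step from the dialdehyde also holds with the second ester, since the ethyl ester gives a 3.6-fold lower number from compound 1 to compound 3 (0.56 log units; beyond the scatter), beyond the scatter, as did the methyl ester in a 4.3-fold lower number from compound 1 to compound 2 (0.63 log units; beyond the scatter), so this difference from compound 1 does not rest on the methyl ester alone. No supporting data are available to account for the flat response to this added methyl.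

As far as these compounds go, a single added carbon is a short probe, so it remains open whether a longer chain such as butyl or benzyl on the ester oxygen would shift the number beyond the scatter. The compounds shown also leave open how a carboxylic acid or an amide in place of the ester would read, and what the remaining formyl group, common to all three compounds, contributes.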